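Ester in place of propargyl ether on the shared core

The source may report more compounds than this note shows. Statements on the series, on what has been measured and on what is new or still open speak of the compounds shown alone.

Measured compounds, all in a functional assay on K562 cells (Homo sapiens) for cytotoxicity, read by MTT assay; on this read-out lower numbers stand for stronger inhibition and higher numbers for weaker inhibition:
- compound 1, `COc1ccc(/C=C/C(=O)c2ccc(OC)c3c2OC(C)(C)C=C3)cc1O`: 630 nM
- compound 2, `C#CCOc1cc(/C=C/C(=O)c2ccc(OC)c3c2OC(C)(C)C=C3)ccc1OC`: > 10000 nM
- compound 3, `CCC(=O)Oc1cc(/C=C/C(=O)c2ccc(OC)c3c2OC(C)(C)C=C3)ccc1OC`: 160 nM

Compound 2 stands at a limit of this assay, (the limit of > 10000 nM in this assay, at which 1 of the 3 values shown sits), so no number is known for it. Relative to compound 1 the change is an at least 15-fold higher number from compound 1 to compound 2 (1.20 log units; beyond the scatter). Compound 3 moves the other way: a 3.9-fold lower number from compound 1 to compound 3 (0.60 log units; beyond the scatter). Among the compounds with values here, the one measured step that ties compound 2 to an ester, an at least 62-fold lower number from compound 2 to compound 3 (1.79 log units; beyond the scatter), is the step most directly relevant here.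

Compound 4, `CCCCC(=O)Oc1cc(/C=C/C(=O)c2ccc(OC)c3c2OC(C)(C)C=C3)ccc1OC`, is not yet measured. Compared with compound 2 the change is butylcarbonyl in place of propargyl on an oxygen on an aromatic ring. Within the data shown here, this repeats the kind of replacement seen from compound 2 to compound 3, with a longer acyl chain, and no measured pair shows how the chain length of the ester itself matters. The expectation for this assay is therefore a large drop in the number, of the same order as the measured propanoyl step, and the step from compound 2 is estimated as an at least 50-fold lower number from compound 2 to compound 4 (1.69 log units; beyond the scatter). For compound 4 the estimate in this assay is 200 nM, expected to lie between 70 nM and 600 nM.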

Compound 4, half-maximal inhibitory concentration: 240 nM
Estimate against measurement, compound 4: 1.2-fold (0.08 log units) below; low and high end bracket the measured number.
By their numbers in this assay, from the lowest: compounds 3 and 4 (each within the scatter of the next); then compound 1. At a limit, above all of these: compound 2.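

In this assay, a second ester on this oxygen again lies far from the propargyl ether, an at least 41-fold lower number from compound 2 to compound 4 (1.61 log units; beyond the scatter), so the large step is not peculiar to propanoyl. Extending the acyl chain from propanoyl to butylcarbonyl gives no difference that can be read: a 1.5-fold higher number from compound 3 to compound 4 (0.18 log units; within the scatter). The free hydroxyl is also left behind by the longer ester, a 2.6-fold lower number from compound 1 to compound 4 (0.42 log units; beyond the scatter), so both esters now stand beyond the scatter from the hydroxyl compound on the lower side, while the ether of compound 2 goes the opposite way.

Going by these compounds, the true size of any step from compound 2 stays unknown, because that compound is known only as a limit: the limit of > 10000 nM in this assay, at which 1 of the 4 values shown sits. Still open is whether the flat response to chain length holds for a longer chain such as octanoyl, for an acetyl ester, or for a benzoyl ester on this oxygen, and whether a plain ethyl ether behaves like the propargyl ether.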